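Alkynyl uracil esters: from benzyl to tert-butyl

The source may report more compounds than this note shows. Statements on the series, on what has been measured and on what is new or still open speak of the compounds shown alone.

Measured compounds:
Compound 1, `CC(=O)OCC(CCn1cc(C#Cc2ccc(Br)cc2)c(=O)n(C(=O)c2ccccc2)c1=O)COC(C)=O`: 28900 nM
Compound 2, `CC(=O)OCC(CCn1cc(C#CCc2ccccc2)c(=O)n(C(=O)c2ccccc2)c1=O)COC(C)=O`: 26800 nM

Compound 1 and compound 2 share one core and differ only at the group on the triple-bonded carbon. In a functional assay on MCF7 cells (Homo sapiens) for antiproliferative activity, read by MTT assay, with a stated time of 72 h (a higher number here means a weaker inhibitor, a lower number a stronger inhibitor), compound 1 gives 28900 nM and compound 2 gives 26800 nM. The step of a 1.1-fold lower number from compound 1 to compound 2 (0.03 log units; within the scatter) is within the scatter, so compound 2 stands with the lowest of the two numbers, but not apart from compound 1.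

Compound 3, `CC(=O)OCC(CCn1cc(C#CC(C)(C)C)c(=O)n(C(=O)c2ccccc2)c1=O)COC(C)=O`, follows the same line: tert-butyl in place of benzyl on a triple-bonded carbon. Going by the values given here, the only measured step that bears on it is a 1.1-fold lower number from compound 1 to compound 2 (0.03 log units; within the scatter), where exchanging one aromatic group for another at the same place changed nothing beyond the scatter. Among the compounds with values here, that step, however, kept a ring on the chain; no measured compound shows what removing the ring altogether does. With that single, flat precedent, the expected step of a 1.1-fold higher number from compound 2 to compound 3 (0.05 log units; within the scatter) is none beyond the scatter, with wide uncertainty. Compound 3 is therefore estimated at 30000 nM in this assay, within the range 10000 nM to 100000 nM.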

Compound 3, half-maximal inhibitory concentration: 67100 nM
Compound 3: middle estimate off by 2.2-fold (0.35 log units), on the low side, within the range that was stated.
By their numbers in this assay, from the lowest: compounds 2 and 1 (each within the scatter of the next); then compound 3.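

In this assay, the group on the triple-bonded carbon turns out not to be indifferent: tert-butyl, which carries no ring, gives a 2.5-fold higher number from compound 2 to compound 3 (0.40 log units; beyond the scatter) when it replaces benzyl and a 2.3-fold higher number from compound 1 to compound 3 (0.37 log units; beyond the scatter) when it replaces 4-bromophenyl. Benzyl and 4-bromophenyl had stayed within the scatter of each other, so only this change shows that the number can move at this position, and it leaves compound 3 as the weakest of the three, although both steps are modest and point toward weaker inhibition only. No measurement is available here that would explain the difference.

The compounds shown leave open whether the shift goes with the loss of the ring or with the branching of tert-butyl, a question that a straight n-butyl chain or a cyclohexyl group at the same place would help to separate. Also open, on these data alone, is whether any group on the triple-bonded carbon, such as a longer chain ending in an amine or a hydroxyl, can bring the number clearly below those of compound 1 and compound 2.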